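Estimating Compound 4 From Three Measured Analogues

The source may hold more compounds than are shown below. What is called first, only, known or untested is meant among the compounds shown, and "the series" means these compounds.

Measured so far in a functional assay on C6 cells (Rattus norvegicus) for cytotoxicity, read by MTT assay, with a stated time of 24 h, tested at 25 ug/mL; a lower number here means a stronger effect, a higher number a weaker effect of the compound at the concentration tested:
compound 1 `O=C(CSc1nnnn1-c1ccccc1)N/N=c1/scc(-c2ccc(Br)cc2)n1-c1ccccc1` gives 47.9%
compound 2 `Cc1nnc(SCC(=O)N/N=c2/scc(-c3ccc(F)cc3)n2-c2ccccc2)s1` gives 50.1%
compound 3 `Cc1ccc(-c2cs/c(=N/NC(=O)CSc3nnnn3-c3ccccc3)n2-c2ccccc2)cc1` gives 38.8%

Compound 3 holds the lowest of the three numbers; its step to compound 1 lies within the scatter, and only the gap to compound 2 goes beyond it. Compound 4 `O=C(CSc1nnnn1-c1ccccc1)N/N=c1/scc(-c2ccc(F)cc2)n1-c1ccccc1` differs from compound 3 in one place: fluoro in place of methyl on an aromatic carbon. Among the measured compounds shown here, the only measured step at this position, a number 9.1 percentage points lower from compound 1 to compound 3 (within the scatter), stayed within the scatter. Compound 2 also carries a fluoro group, but it differs from compound 4 in a second place as well, so its value can only hint. A step of a number 7.2 percentage points higher from compound 3 to compound 4 (within the scatter) is therefore expected, not beyond the scatter. Compound 4 is estimated at 46%, between 34% and 58%.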

Compound 4, a percentage reported as activity, at one concentration (the size of the read-out at that concentration, not a potency): 49.3%
Compound 4: middle estimate off by 3.3 percentage points, on the low side, and the stated range covers the measured number.
By their numbers in this assay, from the lowest: compounds 3, 1, 4 and 2 (each within the scatter of the next, the first and the last beyond it).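

In this assay, among the compounds shown here, going from 4-methylphenyl to 4-fluorophenyl gives a number 10.5 percentage points higher from compound 3 to compound 4 (beyond the scatter) and is the first step at this position to pass the scatter, while fluoro in place of bromo gives only a number 1.4 percentage points higher from compound 1 to compound 4 (within the scatter) and so leaves methyl clear of fluoro but not of bromo. At the other position, 1-phenyl-1H-tetrazol-5-yl in place of 5-methyl-1,3,4-thiadiazol-2-yl on the sulfur gives a number 0.8 percentage points lower from compound 2 to compound 4 (within the scatter) with fluoro held fixed, so this swap shows no readable change. Nothing at hand explains these steps. On these data alone, how a methoxy group or an amine would read at the 4-position of this phenyl ring remains open. As far as these compounds go, whether the sulfur swap stays as small with methyl or bromo in place of fluoro also remains open.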